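Series notes: hydroxy replaced by chloro, compound 3

The source may report more compounds than this note shows. Statements on the series, on what has been measured and on what is new or still open speak of the compounds shown alone.

Two compounds of this series carry measured values. Compound 1 `Cc1ccc2snc(/N=C\c3ccccc3O)c2c1` is read in a functional assay on CCRF-SB cells (Homo sapiens) for antiproliferative activity, read by MTT assay, with a stated time of 96 h (on this read-out lower numbers stand for stronger inhibition and higher numbers for weaker inhibition), and gives 3000 nM. Compound 2 `COc1cccc(/C=N\c2nsc3ccccc23)c1O` gives 5000 nM in this assay. Compound 1 holds the lowest of the two numbers, and its nearest neighbour is compound 2, whose number lies within the scatter of it; on these two values no order between them can be claimed. Among the compounds with values here, no pair of measured compounds that differs in only one place is available, so no measured single-point step exists in this set.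

Compound 3 `Cc1ccc2snc(/N=C\c3ccccc3Cl)c2c1` has not yet been measured in this assay. Against compound 1 the difference is chloro in place of hydroxy on an aromatic carbon. Nothing measured here shows what this change does to the read-out, and the two values at hand set only the range in which the series has so far landed.

The expectation for compound 3 is 5000 nM, with a range of 1500 nM to 20000 nM. The step this estimate implies is a 1.7-fold higher number from compound 1 to compound 3 (0.22 log units; within the scatter), which is expected to be a small move toward a higher number, though possibly none beyond the scatter.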

Compound 3, half-maximal inhibitory concentration: 3000 nM
Estimate against measurement, compound 3: 1.7-fold (0.22 log units) above; measured number inside the range.
By their numbers in this assay, from the lowest: compounds 1, 3 and 2 (each within the scatter of the next).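

Chloro in place of hydroxy on an aromatic carbon, ortho to a large group, gives no change at the digits printed from compound 1 to compound 3 (within the scatter) in this assay and is the first single-point step available for this series. For this pair, the read-out therefore stays within the scatter when hydroxy, counted as a hydrogen-bond donor and acceptor, gives way to chloro, counted with neither, so on this core the hydroxy is not needed to hold the antiproliferative value at this level. Nothing available accounts for this outcome, and the step itself gives no reason for it.

Open questions remain about how far this position tolerates change, since an amine, a carboxylic acid or a longer chain such as ethoxy in the same place could still separate from compound 1 by more than the scatter. Also open, from the compounds shown here alone, is whether the same exchange would leave the read-out equally unmoved on the core of compound 2, which differs from compound 1 in more than one place and so gives no single-point comparison here.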